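Bromo for Methyl on the Benzyl Ring: Expected Cytotoxicity

A few compounds are considered here, and "the series" means these few. Any claim that something is new, unique, unknown or untested is made for them only; others in the source may bear on it.

Compound 1 `CC1(Cc2ccc(C(F)(F)F)cc2)CC(S(=O)(=O)c2ccc(F)cc2)=C(c2ccc(/C(N)=N/O)cc2)O1` gives 103000 nM in an ADME assay on cells (Peritoneal macrophage, Mus musculus, strain Balb/c) for cytotoxicity, read by resazurin assay, with a stated time of 72 h; on this read-out higher numbers stand for lower toxicity in this test and lower numbers for higher toxicity in this test.
Compound 2 `CC1(Cc2ccccc2C(F)(F)F)CC(S(=O)(=O)c2ccc(F)cc2)=C(c2ccc(/C(N)=N/O)cc2)O1` gives 105000 nM in this assay.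
Compound 3 `Cc1ccccc1CC1(C)CC(S(=O)(=O)c2ccc(F)cc2)=C(c2ccc(/C(N)=N/O)cc2)O1` gives 77600 nM in this assay.

Of these three numbers, compound 3 has the lowest, yet both steps reaching it, a 1.3-fold lower number from compound 1 to compound 3 (0.12 log units; within the scatter) and a 1.4-fold lower number from compound 2 to compound 3 (0.13 log units; within the scatter), stay within the scatter, so none of the three can be called more or less toxic than another.

Compound 4 `CC1(Cc2ccccc2Br)CC(S(=O)(=O)c2ccc(F)cc2)=C(c2ccc(/C(N)=N/O)cc2)O1` differs from compound 3 by bromo in place of methyl on an aromatic carbon. The step that bears most on this change is a 1.4-fold lower number from compound 2 to compound 3 (0.13 log units; within the scatter), likewise a swap of one group on an aromatic carbon; the others, a 1.0-fold higher number from compound 1 to compound 2 (0.01 log units; within the scatter) and a 1.3-fold lower number from compound 1 to compound 3 (0.12 log units; within the scatter), also stayed within the scatter. In this assay compound 4 is therefore expected to show no step beyond the scatter, a 1.1-fold higher number from compound 3 to compound 4 (0.04 log units; within the scatter), with an estimated 85000 nM and a range from 45000 nM to 160000 nM.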

Compound 4, half-maximal cytotoxic concentration: 109000 nM
Compound 4: the middle estimate sits 1.3-fold (0.11 log units) below what was measured; the measured number falls inside the stated range.
By their numbers in this assay, from the lowest: compounds 3, 1, 2 and 4 (each within the scatter of the next).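

Replacing methyl with bromo on this aromatic carbon gives no step beyond the scatter in this assay (a 1.4-fold higher number from compound 3 to compound 4 (0.15 log units; within the scatter)). Bromo and trifluoromethyl at this position also cannot be told apart (a 1.0-fold higher number from compound 2 to compound 4 (0.02 log units; within the scatter)), nor can 2-bromophenyl and 4-(trifluoromethyl)phenyl (a 1.1-fold higher number from compound 1 to compound 4 (0.02 log units; within the scatter)), so methyl, trifluoromethyl and bromo at this position all give numbers within the scatter of each other. No measurement shown offers an explanation for this.

From the compounds shown here alone, whether an amine or a carboxylic acid on this aromatic carbon would give a step beyond the scatter remains open. The same question stands for a longer chain there.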